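The source may report more compounds than this note shows. Statements on the series, on what has been measured and on what is new or still open speak of the compounds shown alone.

Measured so far in a functional assay on KYSE-410 cells (Homo sapiens) for antiproliferative activity, read by MTT assay, with a stated time of 72 h; on this read-out lower numbers stand for stronger inhibition and higher numbers for weaker inhibition:

Compound 1 `O=C(Nc1cccc(F)c1)c1cc(=O)[nH]c2cc(Br)ccc12` gives 7300 nM in this assay.
Compound 2 `O=C(Nc1cccc(F)c1)c1cc(=O)[nH]c2cc(F)ccc12` returns only a limit of the assay in this assay, > 20000 nM.
Compound 3 `O=C(Nc1cccc(F)c1)c1cc(=O)[nH]c2cc(-c3ccccc3)ccc12` likewise returns only a limit in this assay, > 20000 nM.

Compound 3 stands at the limit, with no number of its own; (the limit of > 20000 nM in this assay, at which 2 of the 3 values shown sit). Among the compounds with values here, the only readable steps are an at least 2.7-fold higher number from compound 1 to compound 2 (0.43 log units; beyond the scatter) and an at least 2.7-fold higher number from compound 1 to compound 3 (0.43 log units; beyond the scatter), both weakening from the bromo compound. The step that the two limits leave unreadable from compound 2 to compound 3.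

Compound 4 `CC(C)(C)c1ccc(-c2ccc3c(C(=O)Nc4cccc(F)c4)cc(=O)[nH]c3c2)cc1` is not yet measured. It differs from compound 3 by tert-butyl in place of hydrogen on an aromatic carbon. No measured step in the series changes a substituent on the phenyl group, so nothing shown bears directly on this change; the step from compound 2 to compound 3 is itself unreadable. Given that compound 3 sits at the limit, compound 4 is expected to remain near that limit as well, with the step of a number no higher from compound 3 to compound 4 (the limit leaves the size open) estimated to be small or not beyond the scatter. The estimate for compound 4 in this assay is 20000 nM, within 7000 nM to 60000 nM.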

Compound 4, half-maximal inhibitory concentration: > 20000 nM
Compound 4 was reported as a limit; the forecaster's own chance of this, stated with the estimate: 60%; the middle value lies on the limit itself.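

In this assay compound 4 returns only a limit of the assay, > 20000 nM, so tert-butyl on the phenyl group, para to a large group, yields no readable number. Set against the bromo group of compound 1, the change reads as an at least 2.7-fold higher number from compound 1 to compound 4 (0.43 log units; beyond the scatter), while the steps linking compound 2, compound 3 and compound 4 cannot be read. Bromo thus remains the only substituent at this position with a number of its own, and the values now gather at one limit: the limit of > 20000 nM in this assay, at which 3 of the 4 values shown sit.

As far as these compounds go, how far compound 2, compound 3 and compound 4 lie apart stays unknown. Also open, from the compounds shown here alone, is whether an amine or a carboxylic acid on the phenyl group, or chloro or iodo in place of the bromo group, would give a measurable number in this assay.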